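The source may report more compounds than this note shows. Statements on the series, on what has been measured and on what is new or still open speak of the compounds shown alone.

Compound 1 `Cc1ccc(C(=O)Nc2cc(Cl)ccc2OCC(=O)Nc2ccc(S(N)(=O)=O)cc2C)cc1`: 54200 nM
Compound 2 `Cc1cc(S(N)(=O)=O)ccc1NC(=O)COc1ccc(Cl)cc1NC(=O)c1cc(Cl)ccc1Cl`: 42100 nM

In a functional assay on C8166 cells (Homo sapiens) for cytotoxicity, read by MTT assay (a lower number here means that less compound is tolerated, a higher number that more compound is tolerated), compound 2 stands at 42100 nM and is level with compound 1 within the scatter. Compound 3 `Cc1cc(S(N)(=O)=O)ccc1NC(=O)COc1ccc(Cl)cc1NC(=O)c1cc(Cl)cc(Br)c1` carries 3-bromo-5-chlorophenyl in place of 2,5-dichlorophenyl on a carbonyl carbon with the rest of the structure unchanged. Within the data shown here, the only measured step at this place is a 1.3-fold lower number from compound 1 to compound 2 (0.11 log units; within the scatter) and that single step is thin evidence. No shift beyond the scatter is therefore expected in this assay. The estimated step is a 1.1-fold lower number from compound 2 to compound 3 (0.02 log units; within the scatter). Compound 3 is expected at 40000 nM with an estimated range from 18000 nM to 80000 nM.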

Compound 3, half-maximal cytotoxic concentration: 114000 nM
Compound 3: middle estimate off by 2.9-fold (0.45 log units), on the low side; measured number outside the range, above it.
By their numbers in this assay, from the lowest: compounds 2 and 1 (each within the scatter of the next); then compound 3.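

In this assay this position is no longer silent: 3-bromo-5-chlorophenyl on the carbonyl carbon gives a shift beyond the scatter against both earlier groups (a 2.7-fold higher number from compound 2 to compound 3 (0.43 log units; beyond the scatter); a 2.1-fold higher number from compound 1 to compound 3 (0.32 log units; beyond the scatter)), whereas the earlier step stayed within it. Among these three groups, 3-bromo-5-chlorophenyl therefore gives the highest tolerated concentration. Nothing available explains this shift.

Still open, from the compounds shown here alone, is whether the rise depends on the bromine or on the substitution pattern, and whether an amine or a carboxylic acid on this carbonyl carbon would change the number.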